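The source may report more compounds than this note shows. Statements on the series, on what has been measured and on what is new or still open speak of the compounds shown alone.

Working notes on the series. Compound 1 `O/N=C(\CCN1CCN(c2ccccn2)CC1)c1ccccc1` gives in a functional assay on HEK293 cells with D(4) dopamine receptor (Homo sapiens) as the target, read by FLIPR (a lower number here means a smaller maximal response, a higher number a larger maximal response), a value of 70%. Compound 2 `O/N=C(/CCN1CCN(c2ccccn2)CC1)c1ccccc1Cl` gives 64% in this assay, and compound 3 `Cc1cccc(/C(CCN2CCN(c3ccccn3)CC2)=N/O)c1` gives 74% in this assay. Compound 3 thus has the highest of the three numbers, with compound 1 nearest and compound 2 furthest, but both gaps are within the scatter, so no ordering among the three can be claimed. Within the data shown here, the single measured step between compounds differing in one place is a number 4 percentage points higher from compound 1 to compound 3 (within the scatter), which is within the scatter.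

Compound 4 `O/N=C(\CCN1CCN(c2ccccn2)CC1)c1ccc(F)cc1F` differs from compound 3 by 2,4-difluorophenyl in place of 3-methylphenyl on a carbon with a double bond to nitrogen. Among the measured compounds shown here, only one measured step bears on a change of the aromatic substituent, namely a number 4 percentage points higher from compound 1 to compound 3 (within the scatter), and it was within the scatter; no measured step covers fluorine on this ring. Compound 2, which carries chlorine on its aromatic ring, gives 64%, within the scatter of compound 3. On this basis the step in this assay is expected to be a number 8 percentage points lower from compound 3 to compound 4 (within the scatter), not beyond the scatter. Compound 4 is therefore estimated at 66%, with a range of 52% to 80%.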

Compound 4, largest response reached (reported as efficacy), in percent of the reference or control that the assay uses: 78%
Compound 4: the middle estimate sits 12 percentage points below what was measured; low and high end bracket the measured number.
By their numbers in this assay, from the lowest: compounds 2, 1, 3 and 4 (each within the scatter of the next, the first and the last beyond it).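

In this assay 2,4-difluorophenyl in place of 3-methylphenyl gives a number 4 percentage points higher from compound 3 to compound 4 (within the scatter) and in place of phenyl gives a number 8 percentage points higher from compound 1 to compound 4 (within the scatter) so a ring carrying two fluorines on the carbon with a double bond to nitrogen keeps the maximal response within the scatter of both compounds. Among these compounds, compound 2, with chlorine on its ring, gives 64% and compound 4 gives 78% as the only printed values that lie beyond the scatter of each other, so halogen on this ring does not fix a single level of response. Nothing at hand accounts for these results.

The compounds shown leave open whether a group of another kind at this place, such as an amine or a carboxylic acid, would move the response beyond the scatter of compound 1. Also open, going by these compounds, is whether a longer chain in the shared core would shift the response.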